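Replacing 2-(methoxymethyl)phenyl with bromo in compound 3

A few compounds are considered here, and "the series" means these few. Any claim that something is new, unique, unknown or untested is made for them only; others in the source may bear on it.

Measured so far in a physicochemical assay for lipophilicity, read by HPLC, at pH 7.5; on this read-out higher numbers stand for higher lipophilicity and lower numbers for lower lipophilicity:
compound 1 `N#Cc1c(-c2ccc(Br)cc2)nc2cnccc2c1NCC(N)=O` gives 1.9
compound 2 `CC[C@@H](Nc1c(C#N)c(-c2ccc(Br)cc2)nc2cnccc12)C(=O)O` gives 1.6
compound 3 `CC[C@@H](Nc1c(C#N)c(-c2ccc(-c3ccccc3COC)cc2)nc2cnccc12)C(N)=O` gives 2.6

Compound 3 stands highest of the three, beyond the scatter from both others. Compound 4 `CC[C@@H](Nc1c(C#N)c(-c2ccc(Br)cc2)nc2cnccc12)C(N)=O` is not yet measured. It differs from compound 3 by bromo in place of 2-(methoxymethyl)phenyl on an aromatic carbon and nothing else. Among the compounds with values here, the only measured step, a number 0.30 log units lower from compound 1 to compound 2 (within the scatter), changes the group on nitrogen, so it does not test this swap. Still, compound 1 at 1.9 and compound 2 at 1.6 both carry bromo and read lower than compound 3, so a downward step is expected. The estimated step is a number 0.30 log units lower from compound 3 to compound 4 (within the scatter) in size. Compound 4 is expected at 2.3 within an estimated range from 1.9 to 2.7 overall.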

Compound 4, distribution coefficient: 2.2
The estimate for compound 4 lay 0.10 log units above the measured number; measured number inside the range.
By their numbers in this assay, from the lowest: compounds 2, 1 and 4 (each within the scatter of the next, the first and the last beyond it); then compound 3.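

In this assay, within the data shown here, bromo in place of 2-(methoxymethyl)phenyl on this aromatic carbon gives the first direct reading of this position: a number 0.40 log units lower from compound 3 to compound 4 (beyond the scatter). Elsewhere on the molecule, amino in place of hydroxy on the carbonyl carbon gives a number 0.60 log units higher from compound 2 to compound 4 (beyond the scatter), a real difference, whereas ethyl in place of hydrogen on the saturated chain carbon gives a number 0.30 log units higher from compound 1 to compound 4 (within the scatter), too small to count as a change. No measured evidence here accounts for these steps.

Going by these compounds, how much of the step from bromo to 2-(methoxymethyl)phenyl belongs to the ring and how much to its methoxymethyl group remains open. A plain phenyl group on this carbon would separate the two.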